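This account rests on a few compounds, and the source may have more. Where it says the series, first, only, none or still open, it means among the compounds named here.

Working notes on the series. The shared core is carried by compound 1 `Cc1ccc(C(=O)N/N=C/c2cc(I)c(O)c(I)c2)cc1`, compound 2 `CC(C)(C)c1ccc(C(=O)N/N=C/c2cc(I)c(O)c(I)c2)cc1` and the not yet measured compound 3 `O=C(N/N=C/c1cc(I)c(O)c(I)c1)c1ccc(F)cc1`. In a functional assay on HepG2 cells (Homo sapiens) for cytotoxicity, with a stated time of 24 h (on this read-out higher numbers stand for weaker inhibition and lower numbers for stronger inhibition), compound 1 sits at the limit of > 100000 nM in this assay, at which 1 of the 2 values shown sits, and its value > 100000 nM is a limit of the assay rather than a number. Among the measured compounds shown here, compound 2 gives 45900 nM in this assay, the only real number so far, so compound 2 is the sole fixed point. For the measured compounds named here, the single measured step is an at least 2.1-fold lower number from compound 1 to compound 2 (0.33 log units; beyond the scatter), in which the larger group brought the lower number. Compound 3 differs from compound 2 by fluoro in place of tert-butyl on an aromatic carbon. This removes the very tert-butyl that produced the measured step, so the change is expected to run the other way, raising the number. Compound 3 is therefore expected near 90000 nM, within 40000 nM to 200000 nM. The expected step of a 2.0-fold higher number from compound 2 to compound 3 (0.29 log units; within the scatter) would be a weakening, possibly back to the limit.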

Compound 3, half-maximal inhibitory concentration: 117000 nM
The estimate for compound 3 lay 1.3-fold (0.11 log units) below the measured number; the range from low to high includes it.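

In this assay, among the compounds shown here, fluoro in place of tert-butyl on this aromatic carbon gives a 2.5-fold higher number from compound 2 to compound 3 (0.41 log units; beyond the scatter), the first step at this position with a real number at both ends. Among the three compounds, tert-butyl therefore carries the lowest number, against both methyl and fluoro, although the step from methyl has only a limit at one end. The step between compound 1 and compound 3 cannot be read, since compound 1 holds a limit and not a number: the limit of > 100000 nM in this assay, at which 1 of the 3 values shown sits.

As far as these compounds go, whether an amine or a carboxylic acid on this aromatic carbon would bring the number lower than that of compound 2 stays open. From the compounds shown here alone, it also stays open whether the lower number follows tert-butyl alone or extends to other carbon groups, such as isopropyl or a longer chain.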